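Changing the Ring on the Sulfonyl Sulfur

The compounds below may be only part of what the source reports. "The series", "measured", "known", "first", "only" and "open" are said of these compounds alone.

Measured so far in an assay on isolated protein for inhibition of malate dehydrogenase, mitochondrial (Sus scrofa), with stated times of 45 min and 30 min; a higher number here means a weaker inhibitor, a lower number a stronger inhibitor:
compound 1 `O=S(=O)(Nc1ccc(-c2nc3ccccc3o2)cc1)c1ccc(Cl)s1` gives > 63000 nM.
compound 2 `O=S(=O)(Nc1ccc(-c2nc3ccccc3o2)cc1)c1ccc(F)c(C(F)(F)F)c1` gives > 63000 nM.

The value of compound 1, > 63000 nM, is a limit of this assay, not a number. The value of compound 2, > 63000 nM, is likewise only a limit. Compound 1 thus stands at the limit of > 63000 nM in this assay, at which 2 of the 2 values shown sit, and nothing separates it from compound 2 on the numbers shown.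

Compound 3 `O=S(=O)(Nc1ccc(-c2nc3ccccc3o2)cc1)c1ccc(Cl)c(Cl)c1` has not yet been measured in this assay. It differs from compound 1 in one place: 3,4-dichlorophenyl in place of 5-chlorothiophen-2-yl on a sulfonyl sulfur. No measured step of this kind exists among these compounds. Compound 2, which also differs from compound 1 only in the group on the sulfonyl sulfur, gives just a limit, so the expected step is a step that the limit leaves unreadable from compound 1 to compound 3, nothing beyond the scatter. For compound 3 the estimated value is 80000 nM, in the range 20000 nM to 300000 nM, most likely reported again as a limit only.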

Compound 3, half-maximal inhibitory concentration: > 63000 nM
Compound 3 ended at the assay's limit (the forecaster's own chance of this, stated with the estimate: 85%); the middle value does not contradict the limit.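

In this assay compound 3 gives > 63000 nM which is a limit of the assay and not a number. Within the data shown here, compound 1 also gives only a limit, so no step between compound 1 and compound 3 can be read. The compounds shown leave open whether any group on the sulfonyl sulfur gives a measurable inhibition: the limit of > 63000 nM in this assay, at which 3 of the 3 values shown sit.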